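The compounds below may be only part of what the source reports. "The series", "measured", "known", "first", "only" and "open" are said of these compounds alone.

In a physicochemical assay for lipophilicity, read by HPLC, at pH 7.5 (on this read-out higher numbers stand for higher lipophilicity and lower numbers for lower lipophilicity), compound 1 `CC[C@@H](Nc1c(C#N)c(-c2ccc(-c3ccccc3F)cc2)nc2cnccc12)C(N)=O` gives 2.7, compound 2 `CC[C@@H](Nc1c(C#N)c(-c2ccc(-c3cccc(C)c3F)cc2)nc2cnccc12)C(N)=O` gives 3 and compound 3 `CC[C@@H](Nc1c(C#N)c(-c2ccc(-c3ccccc3N(C)C)cc2)nc2cnccc12)C(N)=O` gives 3.2. The two measured steps into compound 3 are a number 0.50 log units higher from compound 1 to compound 3 (beyond the scatter) and a number 0.20 log units higher from compound 2 to compound 3 (within the scatter). Compound 4 `CC[C@@H](Nc1c(C#N)c(-c2ccc(-c3ccccc3COC)cc2)nc2cnccc12)C(N)=O` follows with methoxymethyl in place of dimethylamino on an aromatic carbon, ortho to a large group. Going by the values given here, no measured step makes this exchange directly. The nearest evidence is the dimethylamino-for-fluoro step, a number 0.50 log units higher from compound 1 to compound 3 (beyond the scatter), which sets the likely scale, and a modest fall in this assay is expected on leaving dimethylamino. The expected change is a number 0.40 log units lower from compound 3 to compound 4 (beyond the scatter). The estimate for compound 4 is 2.8, within an expected range of 2.4 to 3.2.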

Compound 4, distribution coefficient: 2.6
Compound 4: the middle estimate sits 0.20 log units above what was measured; the range from low to high includes it.
By their numbers in this assay, from the lowest: compounds 4, 1, 2 and 3 (each within the scatter of the next, the first and the last beyond it).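

In this assay the exchange at this aromatic carbon, ortho to a large group, gives a number 0.60 log units lower from compound 3 to compound 4 (beyond the scatter) even though methoxymethyl and dimethylamino match in heavy atoms and hydrogen-bond acceptors. Compound 4 also shows a number 0.40 log units lower from compound 2 to compound 4 (beyond the scatter) and, with methoxymethyl in place of fluoro, a number 0.10 log units lower from compound 1 to compound 4 (within the scatter) so the step up seen with dimethylamino is not retained with methoxymethyl. No measurement shown here accounts for the difference between the two groups. The compounds shown leave open how a hydroxymethyl, a longer ether chain or a morpholine would read at this position.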